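Dropping a chloro from compound 1 in a PBMC proliferation assay

A few compounds are considered here, and "the series" means these few. Any claim that something is new, unique, unknown or untested is made for them only; others in the source may bear on it.

Measured compounds:
- compound 1, `CCCCCCCCCCCSC(=S)C1=C(Nc2ccc(Cl)cc2Cl)CC(C)(C)CC1=O`: > 50 ug/mL
- compound 2, `CC1(C)CC(=O)C(C(=S)SCc2ccccc2)=C(Nc2ccc(Cl)cc2Cl)C1`: > 50 ug/mL
- compound 3, `CC1(C)CC(=O)C(C(=S)SCCO)=C(Nc2ccc(Cl)cc2Cl)C1`: > 50 ug/mL

All three measured compounds share one core and differ only in the group carried on the sulfur. In a functional assay on PBMC cells (Homo sapiens) for inhibition, read by thymidine incorporation, with a stated time of 72 h (on this read-out higher numbers stand for weaker inhibition and lower numbers for stronger inhibition), compound 1 gives > 50 ug/mL, which is a limit of the assay and not a number. Compound 2 likewise gives > 50 ug/mL in this assay, again a limit. Compound 3 gives > 50 ug/mL in this assay, also a limit. The three steps between them, a step that the two limits leave unreadable from compound 1 to compound 2, a step that the two limits leave unreadable from compound 1 to compound 3 and a step that the two limits leave unreadable from compound 2 to compound 3, therefore cannot be sized, because of the limit of > 50 ug/mL in this assay, at which 3 of the 3 values shown sit.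

Compound 4, `CCCCCCCCCCCSC(=S)C1=C(Nc2ccc(Cl)cc2)CC(C)(C)CC1=O`, keeps the decyl chain of compound 1 and changes only the aromatic ring on the nitrogen: hydrogen in place of chloro on an aromatic carbon. Among the measured compounds shown here, no measured step touches this ring, so nothing shows whether removing one chloro matters. With every measured value sitting at the limit, the plainest expectation is that compound 4 also lands at or around that limit in this assay, with a step from compound 1 estimated as a step that the limit leaves unreadable from compound 1 to compound 4. Compound 4 is expected to give 60 ug/mL, within a range from 20 ug/mL to 200 ug/mL, most likely reported only as a limit.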

Compound 4, half-maximal inhibitory concentration: > 50 ug/mL
Compound 4 ended at the assay's limit; the forecaster's own chance of this, stated with the estimate: 80%; the middle value does not contradict the limit.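

In this assay compound 4 gives > 50 ug/mL, which is a limit of the assay and not a number. No size can be read for the step between compound 1 and compound 4, because both stop at the same point: the limit of > 50 ug/mL in this assay, at which 4 of the 4 values shown sit. The compounds shown leave open how strongly any of them inhibits, and whether the chloro or the group on the sulfur matters at all.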